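Shifting the Pyrazole Attachment in a Urea Series

The source may hold more compounds than are shown below. What is called first, only, known or untested is meant among the compounds shown, and "the series" means these compounds.

Compound 1 `Cc1cc(C)c(NC(=O)N(Cc2cccc(-n3cccc3)c2)C2CCCCCC2)c(C)c1`: in a functional assay on a cell-free system (plasma) with sterol O-acyltransferase, Soat (Rattus norvegicus) as the target (on this read-out lower numbers stand for an effect already at smaller amounts and higher numbers for an effect only at larger amounts of compound), compound 1 gives 0.17 mg/kg
Compound 2 `Cc1cc(C)c(NC(=O)N(Cc2cccc(-c3cc[nH]n3)c2)C2CCCCCC2)c(C)c1`: in this assay compound 2 gives 0.097 mg/kg

Compound 2 holds the lowest of the two numbers, though compound 1 lies within the scatter of it, as a 1.8-fold lower number from compound 1 to compound 2 (0.24 log units; within the scatter) shows. Compound 3 `Cc1cc(C)c(NC(=O)N(Cc2cccc(-c3cn[nH]c3)c2)C2CCCCCC2)c(C)c1` differs from compound 2 by 1H-pyrazol-4-yl in place of 1H-pyrazol-3-yl on an aromatic carbon. For the measured compounds named here, the only measured step, a 1.8-fold lower number from compound 1 to compound 2 (0.24 log units; within the scatter), also swapped a five-membered ring on that aromatic carbon and stayed within the scatter; no measured step moves the attachment within a pyrazole. Compound 3 is therefore expected to stay within the scatter of compound 2, a 1.1-fold higher number from compound 2 to compound 3 (0.05 log units; within the scatter). The estimate for compound 3 is 0.11 mg/kg, with a range from 0.045 mg/kg to 0.27 mg/kg.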

Compound 3, dose for half-maximal effect: 0.19 mg/kg
Estimate against measurement, compound 3: 1.7-fold (0.24 log units) below; low and high end bracket the measured number.
By their numbers in this assay, from the lowest: compounds 2, 1 and 3 (each within the scatter of the next).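

Moving the attachment within the pyrazole, with 1H-pyrazol-4-yl in place of 1H-pyrazol-3-yl on this aromatic carbon, gives a 2.0-fold higher number from compound 2 to compound 3 (0.29 log units; within the scatter) in this assay and is the first step of its kind here. Exchanging 1H-pyrrol-1-yl for 1H-pyrazol-4-yl gives a 1.1-fold higher number from compound 1 to compound 3 (0.05 log units; within the scatter) on the same carbon, so all three five-membered rings stay within the scatter of one another. No evidence at hand bears on these results. The compounds shown leave open whether an amine or a carboxylic acid on this aromatic carbon would move the number beyond the scatter.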